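The source may report more compounds than this note shows. Statements on the series, on what has been measured and on what is new or still open speak of the compounds shown alone.

Compound 2 `CCc1ccc(NC(=O)N[C@H](C)c2ccccc2)cc1` is the starting point of this step. In an ADME assay on the whole organism with Oryza sativa as the target, tested at 0.1 uM (on this read-out higher numbers stand for a weaker effect at the one concentration tested and lower numbers for a stronger effect), compound 2 gives 95%. Only two numbers are shown so far; in this assay compound 1 `Cc1ccc(NC(=O)N[C@H](C)c2ccccc2)cc1` gives 100%, and the two values sit within the usual scatter of one another, so neither is set apart. Compound 3 `CC(C)c1ccc(NC(=O)N[C@H](C)c2ccccc2)cc1` has not yet been measured; it differs from compound 2 by methyl in place of hydrogen on a saturated chain carbon bound to an aromatic carbon and a saturated chain carbon. Within the data shown here, one measured step bears on this change, since it too is a methyl in place of hydrogen on a saturated chain carbon bound to an aromatic carbon: a number 5 percentage points lower from compound 1 to compound 2 (within the scatter). That step stayed within the scatter. The step from compound 2 to compound 3 is therefore expected to be no change at the digits printed from compound 2 to compound 3 (within the scatter), none beyond the scatter in either direction. Compound 3 is accordingly estimated to give 95% in this assay, with a likely range from 82% to 100%.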

Compound 3, a percentage reported as activity, at one concentration (the size of the read-out at that concentration, not a potency): 99%
Compound 3: middle estimate off by 4 percentage points, on the low side; the measured number falls inside the stated range.
By their numbers in this assay, from the lowest: compounds 2, 3 and 1 (each within the scatter of the next).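

In this assay, going from ethyl to isopropyl gives a number 4 percentage points higher from compound 2 to compound 3 (within the scatter), so a second methyl on this saturated chain carbon moves the number no further than the first did. The wider change, isopropyl in place of methyl on an aromatic carbon, gives a number 1 percentage points lower from compound 1 to compound 3 (within the scatter), which shows that even the two ends of this short series cannot be told apart. Nothing measured explains why these groups read alike.

The compounds leave open whether any group at this place would shift the read-out beyond the scatter, for instance a longer chain, an amine or a carboxylic acid. With a single concentration in a single assay, they also say nothing about potency across a range of concentrations.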